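The source may report more compounds than this note shows. Statements on the series, on what has been measured and on what is new or still open speak of the compounds shown alone.

Compound 1 `O=C1O/C(=C\Cn2cc(Cc3ccccc3)nn2)C(OCc2ccccc2)=C1OCc1ccccc1` gives 29200 nM in a functional assay on MDA-MB-231 cells (Homo sapiens) for antiproliferative activity, read by MTT assay, with a stated time of 24 h; on this read-out higher numbers stand for weaker inhibition and lower numbers for stronger inhibition. Compound 2 `O=C1NC(O)(CCn2cc(-c3ccccc3)nn2)C(OCc2ccccc2)=C1OCc1ccccc1` gives 21100 nM in this assay. For compound 3 `Cc1ccc(-c2cn(C/C=C3\OC(=O)C(OCc4ccccc4)=C3OCc3ccccc3)nn2)cc1` this assay reports only a limit, > 100000 nM.

Compound 2 stands at the lowest of the two numbers, with compound 1 within the scatter of it. Compound 4 `O=C1NC(O)(CCn2cc(Cc3ccccc3)nn2)C(OCc2ccccc2)=C1OCc1ccccc1` differs from compound 2 by benzyl in place of phenyl on an aromatic carbon. Among the measured compounds shown here, the one measured step that bears on this change runs the opposite way: an at least 3.4-fold higher number from compound 1 to compound 3 (0.53 log units; beyond the scatter), which replaced benzyl with a ring group on an aromatic carbon and weakened inhibition, as far as the limit of > 100000 nM in this assay, at which 1 of the 3 values shown sits, allows one to say. Putting benzyl back in compound 4 is therefore expected to leave the number unchanged or somewhat lower, a 1.4-fold lower number from compound 2 to compound 4 (0.15 log units; within the scatter). Compound 4 is estimated at 15000 nM, between 6000 nM and 40000 nM.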

Compound 4, half-maximal inhibitory concentration: > 100000 nM
Compound 4: only a limit was reported; the forecaster's own chance of this, stated with the estimate: 5%; middle value at least 6.6-fold (0.82 log units) from the limit.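

Benzyl in place of phenyl on this aromatic carbon gives an at least 4.7-fold higher number from compound 2 to compound 4 (0.67 log units; beyond the scatter), so benzyl does not go with the lower number on every core. The earlier step, an at least 3.4-fold higher number from compound 1 to compound 3 (0.53 log units; beyond the scatter), had left benzyl on the favourable side, and the two steps now point opposite ways. Compound 4 is reported only as a limit, so the true size of its step stays unknown: the limit of > 100000 nM in this assay, at which 2 of the 4 values shown sit.

Still open, as far as these compounds go, is how plain phenyl behaves on the core of compound 1. Also open, from the compounds shown here alone, is whether a longer chain such as 2-phenylethyl on this carbon would keep a measurable number on the core of compound 2.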